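Notes on a bicyclic replacement in the series

The compounds below may be only part of what the source reports. "The series", "measured", "known", "first", "only" and "open" are said of these compounds alone.

Measured so far:
compound 1 `CCn1cc(CN2CCN(c3cccn4cc(-c5ccc(C(C)(C)C)cc5)nc34)CC2)c(=O)[nH]c1=O`: 5 nM
compound 2 `CC(C)(C)c1ccc(-c2cn3cccc(N4CCN(Cc5cnc6ccccc6n5)CC4)c3n2)cc1`: 39 nM

Both compounds were run in a functional assay for antagonist activity at Gonadotropin-releasing hormone receptor (Homo sapiens), with a stated time of 1 h; a lower number here means a stronger inhibitor, a higher number a weaker inhibitor. For the measured compounds named here, compound 1 gives 5 nM and holds the lowest of the two numbers; its only neighbour is compound 2, which gives 39 nM, and the step of a 7.8-fold higher number from compound 1 to compound 2 (0.89 log units; beyond the scatter) is modest but clearly beyond the scatter.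

Compound 3 `CC(C)(C)c1ccc(-c2cn3cccc(N4CCN(Cc5ccc6nccnc6c5)CC4)c3n2)cc1` differs from compound 1 in one place: a group of 10 heavy atoms (8 carbon, 2 nitrogen; one six-membered aromatic ring of carbon only, one six-membered aromatic ring with 2 hetero atoms) in place of a group of 10 heavy atoms (6 carbon, 2 nitrogen, 2 oxygen; one six-membered aromatic ring with 2 hetero atoms), on a saturated chain carbon bound to an amine nitrogen in a ring. Going by the values given here, the single measured step that bears on this change is a 7.8-fold higher number from compound 1 to compound 2 (0.89 log units; beyond the scatter), in which a group of the same kind entered at the same place and the number went up. Among the compounds with values here, no further step of this type is available, so the expectation rests on that one comparison alone. A step of comparable size and in the same direction is expected, namely a 6.0-fold higher number from compound 1 to compound 3 (0.78 log units; beyond the scatter). Compound 3 is therefore estimated at 30 nM, with a range from 8 nM to 120 nM.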

Compound 3, half-maximal inhibitory concentration: 90 nM
For compound 3 the middle estimate is 3.0-fold (0.48 log units) below the measured one, within the range that was stated.
By their numbers in this assay, from the lowest: compound 1; then compound 2; then compound 3.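

In this assay a second bicyclic group at this place, on a saturated chain carbon bound to an amine nitrogen in a ring, also raises the number relative to the group of compound 1, with an 18-fold higher number from compound 1 to compound 3 (1.26 log units; beyond the scatter) as the result. The change from one quinoxaline attachment to the other is itself readable: quinoxalin-6-yl in place of quinoxalin-2-yl gives a 2.3-fold higher number from compound 2 to compound 3 (0.36 log units; beyond the scatter), so the number at this place follows more than the heavy-atom count, which is the same in all three groups. No measurement at hand accounts for either step.

Going by these compounds, whether the lower number of compound 1 depends on its amide hydrogen remains open, and a methyl group in that place on the same ring would test it. A quinoline at this place would show whether a single ring nitrogen in the bicyclic group changes the picture.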